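The compounds below may be only part of what the source reports. "The series", "measured", "known", "first", "only" and "open" are said of these compounds alone.

Measured in a functional assay on MCF7 cells (Homo sapiens) for cytotoxicity; a lower number here means a stronger inhibitor, a higher number a weaker inhibitor:
- Compound 1 `COc1ccc2nc(NC(=O)CCCCC(=O)NO)sc2c1`: 5.91 ug/mL
- Compound 2 `O=C(CCCCCCC(=O)Nc1nc2ccccc2s1)NO`: 6.61 ug/mL
- Compound 3 `CS(=O)(=O)c1ccc2nc(NC(=O)CCCCCCC(=O)NO)sc2c1`: 15.4 ug/mL

Compound 3 has the highest number of the three, which makes it the weakest inhibitor so far in this assay. The next compound to test, compound 4 `CS(=O)(=O)c1ccc2nc(NC(=O)CCCCC(=O)NO)sc2c1`, keeps the methylsulfonyl group of compound 3 and changes only the chain: hydroxycarbamoyl in place of 2-(hydroxycarbamoyl)ethyl on a saturated chain carbon, four bonds along the chain from a carbonyl carbon. In words, hydroxycarbamoyl stands in place of 2-(hydroxycarbamoyl)ethyl on a saturated chain carbon, four bonds along the chain from a carbonyl carbon.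

Among the measured compounds shown here, no measured step changes the chain alone. For the measured compounds named here, the one measured step, a 2.3-fold higher number from compound 2 to compound 3 (0.37 log units; beyond the scatter), concerns the methylsulfonyl group, and compound 4 retains that group, so this step suggests a number nearer compound 3 than compound 2. Compound 1 carries the same chain as compound 4 but differs from it on the shared core. Compound 1 at 5.91 ug/mL lies within the scatter of compound 2 at 6.61 ug/mL, and compound 2 carries the longer chain. That gives no sign of a large chain effect, though the comparison is not clean. No change beyond the scatter is therefore expected. The estimated step is a 1.2-fold lower number from compound 3 to compound 4 (0.07 log units; within the scatter). For compound 4 the expected value is 13 ug/mL, with an estimated range of 6 ug/mL to 28 ug/mL.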

Compound 4, half-maximal inhibitory concentration: > 30 ug/mL
Compound 4 gave a limit, no number (the forecaster's own chance of this, stated with the estimate: 3%); middle value at least 2.3-fold (0.36 log units) from the limit.
By their numbers in this assay, from the lowest: compounds 1 and 2 (each within the scatter of the next); then compound 3. At a limit, above all of these: compound 4.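

Compound 4 gave a limit in this assay, not a number: the limit of > 30 ug/mL in this assay, at which 1 of the 4 values shown sits. Among the compounds shown here, with the methylsulfonyl group kept, hydroxycarbamoyl in place of 2-(hydroxycarbamoyl)ethyl on a saturated chain carbon is the first change to the chain alone, and it gives an at least 1.9-fold higher number from compound 3 to compound 4 (0.28 log units; that floor lies within the scatter); this floor alone does not show that the chain matters, though the true step may be larger. With the shorter chain kept, methylsulfonyl in place of methoxy on an aromatic carbon gives an at least 5.0-fold higher number from compound 1 to compound 4 (0.70 log units; beyond the scatter), so on this chain the change on the shared core already clears the scatter, however far past the limit the true value of compound 4 lies.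

From the compounds shown here alone, without a number for compound 4, the true size of both steps stays unknown, as does whether the effect of the chain depends on the methylsulfonyl group. The compounds shown also say nothing about an amine or a carboxylic acid in place of methylsulfonyl on that aromatic carbon, or about a chain longer than the one in compound 3.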